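Notes on a small agonist series: lactam in place of sulfone

A few compounds are considered here, and "the series" means these few. Any claim that something is new, unique, unknown or untested is made for them only; others in the source may bear on it.

Measured compounds:
compound 1, `CC(C)c1noc(N2CCC(Oc3cc(N4CCc5cc([S+]([O-])CCO)ccc54)ncn3)CC2)n1`; in an assay on CHO cells for agonist activity at Glucose-dependent insulinotropic receptor (Homo sapiens), read by a luciferase reporter and cAMP accumulation, with a stated time of 2 h (a higher number here means that more compound is needed for the effect, a lower number that less compound is needed), compound 1 gives 48 nM
compound 2, `CC(C)c1noc(N2CCC(Oc3cc(N4CCc5cc(S(=O)(=O)CCO)ccc54)ncn3)CC2)n1`; in this assay compound 2 gives 41 nM

Within the data shown here, compound 2 stands at the lowest of the two numbers, but the single step that reaches it, a 1.2-fold lower number from compound 1 to compound 2 (0.07 log units; within the scatter), is within the scatter, so compound 1 and compound 2 cannot be told apart on these data.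

Compound 3, `CC(C)c1noc(N2CCC(Oc3cc(N4CCc5cc(N6CCC(O)CC6=O)ccc54)ncn3)CC2)n1`, is not yet measured. It differs from compound 2 by 4-hydroxy-2-oxopiperidin-1-yl in place of (2-hydroxyethyl)sulfonyl on an aromatic carbon. Among the measured compounds shown here, the only measured step touches this same position: the move from sulfinyl to sulfonyl left the number essentially unchanged. For the measured compounds named here, that step is the sole piece of evidence that bears on the new change, and it is a much smaller change than the present one, which exchanges an open chain for a six-membered ring carrying a carbonyl. Going by the values given here, no measured pair covers such an exchange.

Expectation for compound 3 in this assay is therefore a step of about a 1.5-fold higher number from compound 2 to compound 3 (0.17 log units; within the scatter), that is, no change beyond the scatter, with a wide band of uncertainty. The estimate for compound 3 is 60 nM, with a range from 15 nM to 250 nM.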

Compound 3, half-maximal effective concentration: 89 nM
For compound 3 the middle estimate is 1.5-fold (0.17 log units) below the measured one; low and high end bracket the measured number.
By their numbers in this assay, from the lowest: compounds 2, 1 and 3 (each within the scatter of the next, the first and the last beyond it).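

Working from this assay, 4-hydroxy-2-oxopiperidin-1-yl in place of (2-hydroxyethyl)sulfonyl gives a 2.2-fold higher number from compound 2 to compound 3 (0.34 log units; beyond the scatter) and so provides the first step in the series beyond the scatter, though only a modest one. Set against the sulfinyl group of compound 1, the same ring gives a 1.9-fold higher number from compound 1 to compound 3 (0.27 log units; within the scatter) and stays inside the scatter, so the ring separates from the sulfonyl compound but not from the sulfinyl compound, and this aromatic carbon carries a six-membered non-aromatic ring without sulfur while the number stays of the same order. No measured information on these compounds accounts for the size of this step.

Among these compounds, the three compounds do not show whether the step follows from the ring, its carbonyl or its hydroxyl, as these parts enter together and no compound carries one without the others. Also open, as far as these compounds go, is how the number responds at this position to a plain piperidin-1-yl group, a carboxylic acid, or a longer hydroxyalkyl chain on the sulfonyl group.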